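The source may hold more compounds than are shown below. What is called first, only, known or untested is meant among the compounds shown, and "the series" means these compounds.

Compound 2 `O=C(/C(=C\c1ccc(Cl)cc1)SCc1ccc(Cl)cc1)c1ccc(Br)cc1` and compound 1 `Cc1ccc(S/C(=C/c2ccc(Cl)cc2)C(=O)c2ccc(Br)cc2)cc1` share one core, while compound 3 `O=C(/C(=C\c1c(O)cc(O)cc1O)SCc1ccc(Cl)cc1)c1ccc(Cl)cc1` and compound 4 `Cc1ccc(S/C(=C/c2c(O)cc(O)cc2O)C(=O)c2ccc(Cl)cc2)cc1` share another; the difference between the two cores is not broken down here. In a functional assay on DU-145 cells (Homo sapiens) for inhibition, read by trypan blue exclusion, with a stated time of 96 h (on this read-out lower numbers stand for stronger inhibition of growth and higher numbers for weaker inhibition of growth), compound 2 gives 10000 nM. In this assay compound 1 gives 10000 nM. The change between them, (4-methylphenyl in place of 4-chlorobenzyl on a sulfur), made the step of no change at the digits printed from compound 2 to compound 1 (within the scatter). For compound 3 only a limit of this assay is known, reported as > 100000 nM, and this is a limit rather than a number, as the limit of > 100000 nM in this assay, at which 1 of the 3 values shown sits, records. Compound 4 carries the same change, (4-methylphenyl in place of 4-chlorobenzyl on a sulfur). Resting on the earlier step of no change at the digits printed from compound 2 to compound 1 (within the scatter), the corresponding step is expected to be a step that the limit leaves unreadable from compound 3 to compound 4. Compound 4 is therefore estimated at about 150000 nM, most likely again reported as a limit, with an expected range from 60000 nM to 400000 nM.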

Compound 4, concentration for 50% growth inhibition: > 100000 nM
Compound 4 ended at the assay's limit (the forecaster's own chance of this, stated with the estimate: 80%); the middle value is on the limit's open side.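

No step can be read between compound 3 and compound 4, because both rest on a limit rather than a number: the limit of > 100000 nM in this assay, at which 2 of the 4 values shown sit. The compounds shown leave open whether 4-methylphenyl in place of 4-chlorobenzyl on a sulfur changes growth inhibition on this core.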